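Removing a ring methyl: the cytotoxicity limit is expected to hold

The compounds below may be only part of what the source reports. "The series", "measured", "known", "first", "only" and "open" are said of these compounds alone.

Compound 1 `CCON=C1CCC(CN2CCN(c3nc(=O)c4cc(C(F)(F)F)cc([N+](=O)[O-])c4s3)CC2)CC1`, compound 2 `CCON=C1CCC(CN2CCN(c3nc(=O)c4cc(C(F)(F)F)cc([N+](=O)[O-])c4s3)C[C@H]2C)CC1` and compound 3 `CON=C1CCC(CN2C(C)CN(c3nc(=O)c4cc(C(F)(F)F)cc([N+](=O)[O-])c4s3)CC2C)CC1` were all tested in an ADME assay on Vero cells (Chlorocebus sabaeus) for cytotoxicity; on this read-out higher numbers stand for lower toxicity in this test and lower numbers for higher toxicity in this test. In this assay compound 1 gives only a limit, > 64 ug/mL. Compound 2 also gives only a limit, > 64 ug/mL. Compound 3 too reaches only a limit, > 64 ug/mL. Compound 1 differs from compound 2 by hydrogen in place of methyl on a saturated ring carbon, and the size of a step that the two limits leave unreadable from compound 2 to compound 1 cannot be read because both values sit at the limit of > 64 ug/mL in this assay, at which 3 of the 3 values shown sit. The difference between the cores of compound 2 and compound 3 is not broken down here.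

Compound 4 `CON=C1CCC(CN2CCN(c3nc(=O)c4cc(C(F)(F)F)cc([N+](=O)[O-])c4s3)CC2C)CC1` has not yet been measured. It differs from compound 3 by hydrogen in place of methyl on a saturated ring carbon. This is the same kind of change as that made from compound 2 to compound 1, though here the place also lies two ring bonds from the ring atom that bears a methyl group (1 heavy atom), which is absent in the earlier case.

In this assay compound 4 is expected to show the step that the limit leaves unreadable from compound 3 to compound 4. That expectation rests on all three measured compounds sitting at the limit of > 64 ug/mL in this assay, at which 3 of the 3 values shown sit. Compound 4 is therefore estimated at 80 ug/mL, most probably again reported only as a limit.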

Compound 4, half-maximal cytotoxic concentration: > 64 ug/mL
Compound 4: only a limit was reported; the forecaster's own chance of this, stated with the estimate: 85%; the middle value does not contradict the limit.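

In this assay compound 4 gives > 64 ug/mL as a limit only. The step from compound 3 to compound 4 cannot be read, because both compounds sit at the same limit: the limit of > 64 ug/mL in this assay, at which 4 of the 4 values shown sit. The compounds shown leave open how far each lies beyond that limit, and so whether hydrogen in place of methyl changes cytotoxicity here at all.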